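The source may hold more compounds than are shown below. What is called first, only, known or untested is meant among the compounds shown, and "the series" means these compounds.

Measured compounds:
- compound 1, `O=C(O)CC/C=C\CO[C@@H]1C(OCc2ccc(-c3ccccc3)cc2)CC[C@@H]1N1CCCCC1`: 39.8 nM in a functional assay on blood for antagonist activity at thromboxane A2 receptor (Homo sapiens); a lower number here means tighter binding, a higher number weaker binding
- compound 2, `O=C(O)CC/C=C\CO[C@H]1C(OCc2ccc(-c3ccccc3)cc2)CC[C@@H]1N1CCCCC1`: 63.1 nM; 15.9 nM (2 entries) in this assay
- compound 3, `NC(=O)c1ccccc1-c1ccc(COC2CC[C@H](N3CCCCCC3)[C@H]2OC/C=C\CCC(=O)O)cc1`: 15.9 nM in this assay

All three were tested in this assay, which reports a dissociation constant. Compound 3 has the lower of the two single numbers; the other single number belongs to compound 1, and the gap between them lies beyond the usual scatter. Compound 2 carries several entries (the several entries of compound 2 in this assay, 63.1 nM; 15.9 nM (2 entries)) and so stands without one single number, which is why it is not ranked against compound 3.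

The next compound, compound 4, `O=C(O)CC/C=C\CO[C@H]1C(OCc2ccc(-c3ccccc3CO)cc2)CC[C@@H]1N1CCCCCC1`, has not yet been measured. It differs from compound 3 in one place: hydroxymethyl in place of carbamoyl on an aromatic carbon. Both the leaving group and the entering group carry one hydrogen-bond donor and one hydrogen-bond acceptor, and the entering group is one heavy atom smaller. Among the measured compounds shown here, no measured pair in this set changes the same place, so no measured step shows what this swap does. Without such a guide, a step is expected that stays within the scatter, with no clear direction: the change expected is a 1.4-fold higher number from compound 3 to compound 4 (0.14 log units; within the scatter). Compound 4 is therefore expected to give 22 nM, with a likely range from 8 nM to 63 nM.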

Compound 4, dissociation constant: 3.16 nM
The estimate for compound 4 lay 7.0-fold (0.84 log units) above the measured number; the measured number lies below the stated range.
By their numbers in this assay, from the lowest: compound 4; then compound 3; then compound 1.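

Among the compounds shown here, this is the first measured step at this place, an aromatic carbon ortho to a large group, and it shows that the place is not indifferent to what sits there: replacing carbamoyl with hydroxymethyl gives a 5.0-fold lower number from compound 3 to compound 4 (0.70 log units; beyond the scatter) in this assay. The two groups have the same count of hydrogen-bond donors and acceptors, one of each, and differ by a single heavy atom. Matching those counts did not keep the number the same. Nothing shown accounts for the direction or the size of this step.

A single step cannot separate what is lost with the carbamoyl from what is gained with the hydroxymethyl, and it cannot show whether the same swap would give a similar step on a different core. It also leaves open how this place responds to other groups, such as methoxymethyl, a carboxylic acid, an amine like aminomethyl, or a longer chain like 2-hydroxyethyl.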